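The source may hold more compounds than are shown below. What is called first, only, known or untested is meant among the compounds shown, and "the series" means these compounds.

Working notes on the shared core series in an assay on isolated protein for inhibition of acid-sensing ion channel 3 (Homo sapiens), read by patch clamp; on this read-out higher numbers stand for weaker inhibition and lower numbers for stronger inhibition. Compound 1 `N=C(N)c1ccc2[nH]c(-c3cc(F)cc(Br)c3)cc2c1` gives 59000 nM in this assay. Compound 2 `Cc1cc(Cl)cc(-c2cc3cc(C(=N)N)ccc3[nH]2)c1` gives 51000 nM in this assay. Compound 3 `COc1cc(F)cc(-c2cc3cc(C(=N)N)ccc3[nH]2)c1` gives 374000 nM in this assay, which is the highest of the three numbers; compound 1 lies nearest to it and compound 2 furthest, and both gaps exceed the scatter. Compound 1 and compound 2 show numbers that lie within the scatter of each other.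

Compound 4 `N=C(N)c1ccc2[nH]c(-c3cc(F)cc(Cl)c3)cc2c1` has not yet been measured. Against compound 3 the change is chloro in place of methoxy on an aromatic carbon. Going by the values given here, the one measured step that bears directly on it is the same exchange run the other way on the same aromatic carbon, a 6.3-fold higher number from compound 1 to compound 3 (0.80 log units; beyond the scatter), a modest rise. Among the compounds with values here, compound 2 carries chloro on that ring alongside methyl rather than fluoro, so no single step from it to compound 4 can be drawn, but its value sits close to that of compound 1. Putting a halogen back in place of methoxy is therefore expected to undo most of that rise, a step of about a 6.2-fold lower number from compound 3 to compound 4 (0.79 log units; beyond the scatter) in this assay. Compound 4 is estimated at 60000 nM in this assay, with a likely range from 25000 nM to 150000 nM.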

Compound 4, half-maximal inhibitory concentration: 278000 nM
Compound 4: middle estimate off by 4.6-fold (0.67 log units), on the low side, outside the stated range (above it).
By their numbers in this assay, from the lowest: compounds 2 and 1 (each within the scatter of the next); then compounds 4 and 3 (each within the scatter of the next).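

The step of a 1.3-fold lower number from compound 3 to compound 4 (0.13 log units; within the scatter) shows that chloro and methoxy on this aromatic carbon cannot be told apart in this assay, so the rise seen in a 6.3-fold higher number from compound 1 to compound 3 (0.80 log units; beyond the scatter) does not mark methoxy out from the halogens as a class. The step of a 4.7-fold higher number from compound 1 to compound 4 (0.67 log units; beyond the scatter) shows instead that this position separates bromo from chloro when a fluoro group is held on the same ring, with compound 4 reading alongside compound 3 and not alongside compound 1. The step of a 5.5-fold higher number from compound 2 to compound 4 (0.74 log units; beyond the scatter) adds that chloro alone does not set the level: with chloro held, the number depends on whether the other aromatic carbon carries methyl or fluoro, so compound 2 and compound 1 reach their similar values with different pairs of groups.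

The compounds shown leave open whether methyl and bromo together would go lower than either pair, and how an amine, a hydroxyl group or an ethyl group would read on this carbon. No measurement here accounts for why bromo and chloro part at this position.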